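Lengthening the unsaturated amide chain: compound 3 to compound 4

The compounds below may be only part of what the source reports. "The series", "measured", "known", "first", "only" and "open" are said of these compounds alone.

Measured compounds:
compound 1 `C=CC(=O)Nc1cc(Nc2nc(C)cc(-c3cn(C)c4ccccc34)n2)c(OC)cc1N(C)CCN(C)C` — 2910 nM
compound 2 `C=C(Cl)C(=O)Nc1cc(Nc2nc(C)cc(-c3cn(C)c4ccccc34)n2)c(OC)cc1N(C)CCN(C)C` — 1730 nM
compound 3 `CC/C=C\C(=O)Nc1cc(Nc2nc(C)cc(-c3cn(C)c4ccccc34)n2)c(OC)cc1N(C)CCN(C)C` — 1090 nM

In a functional assay on A549 cells (Homo sapiens) for antiproliferative activity, read by MTT assay, with a stated time of 72 h (on this read-out lower numbers stand for stronger inhibition and higher numbers for weaker inhibition), compound 1 gives 2910 nM, compound 2 gives 1730 nM and compound 3 gives 1090 nM. Compound 3 stands apart from compound 1 by a 2.7-fold lower number from compound 1 to compound 3 (0.43 log units; beyond the scatter), a step beyond the scatter, but is separated from compound 2 only by a 1.6-fold lower number from compound 2 to compound 3 (0.20 log units; within the scatter), which lies within it.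

Compound 4 `CCC/C=C\C(=O)Nc1cc(Nc2nc(C)cc(-c3cn(C)c4ccccc34)n2)c(OC)cc1N(C)CCN(C)C` differs from compound 3 by methyl in place of hydrogen on a saturated chain carbon, two bonds along the chain from a double-bonded chain carbon; cut one bond further out, the same difference reads but-1-en-1-yl to pent-1-en-1-yl. The measured step that bears on this change is the earlier lengthening of the same chain, a 2.7-fold lower number from compound 1 to compound 3 (0.43 log units; beyond the scatter), a modest lowering of the number. The exchange of chloro for the longer chain, a 1.6-fold lower number from compound 2 to compound 3 (0.20 log units; within the scatter), is within the scatter and adds little guidance. One further methyl on a chain that has already been lengthened once is expected to bring at most a small lowering in this assay, quite possibly none beyond the scatter, and the estimated step is a 1.2-fold lower number from compound 3 to compound 4 (0.08 log units; within the scatter). Compound 4 is therefore estimated at 900 nM, with a range from 400 nM to 2000 nM.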

Compound 4, half-maximal inhibitory concentration: 329 nM
Estimate against measurement, compound 4: 2.7-fold (0.44 log units) above; the measured number lies below the stated range.
By their numbers in this assay, from the lowest: compound 4; then compounds 3, 2 and 1 (each within the scatter of the next, the first and the last beyond it).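

In this assay, methyl in place of hydrogen on a saturated chain carbon, two bonds along the chain from a double-bonded chain carbon, proved to be more than a marginal change: a 3.3-fold lower number from compound 3 to compound 4 (0.52 log units; beyond the scatter) lies beyond the scatter, showing that the outer end of this chain still affects the read-out after the earlier lengthening, a 2.7-fold lower number from compound 1 to compound 3 (0.43 log units; beyond the scatter). Against the shorter acyl groups, pent-1-en-1-yl in place of vinyl gives an 8.8-fold lower number from compound 1 to compound 4 (0.95 log units; beyond the scatter) and pent-1-en-1-yl in place of 1-chloroethenyl gives a 5.3-fold lower number from compound 2 to compound 4 (0.72 log units; beyond the scatter), which makes compound 4 the most potent of these four compounds and places it clearly apart from all three. Nothing presented here accounts for why one added carbon at this position has this effect.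

The compounds shown leave open whether the number keeps falling with a longer chain such as hex-1-en-1-yl or rises again, and whether a branched chain such as 4-methylpent-1-en-1-yl would behave like the straight one. They also leave open how the opposite double-bond geometry of pent-1-en-1-yl, or a dimethylamino group at the end of the chain, would read in this assay.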